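The source may hold more compounds than are shown below. What is called first, only, known or untested is meant among the compounds shown, and "the series" means these compounds.

Working notes on the series. In a functional assay on the whole organism (strain Wistar) for inhibition, with Rattus norvegicus as the target, read by paw edema, with stated times of 30 min and 5 h, at a dose of 0.05 mmol/kg by the oral route (a lower number here means less inhibition, a higher number more inhibition at the dose given (going by the name of the read-out)), compound 1 `CS(=O)(=O)c1ccc(N2N=C(c3ccc(Oc4ccccc4)cc3)CCC2=O)cc1` gives 65.7%, while compound 2 `CS(=O)(=O)c1ccc(N2N=C(c3ccc(Cl)c(Cl)c3)CCC2=O)cc1` gives 34.2% and stands lowest of the two numbers, its nearest neighbour compound 1 lying higher by a gap beyond the usual scatter. Compound 3 `CS(=O)(=O)c1ccc(N2N=C(c3ccc(F)cc3)CCC2=O)cc1` has not yet been measured; it differs from compound 2 by 4-fluorophenyl in place of 3,4-dichlorophenyl on a carbon with a double bond to nitrogen. Going by the values given here, with only two measured compounds and no single-change step between them, the size of the move in this assay is open; a modest upward step is expected, a number 10.8 percentage points higher from compound 2 to compound 3 (beyond the scatter), but one within or just beyond the scatter would not surprise. Compound 3 is estimated at 45%, with a range from 25% to 65%.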

Compound 3, a percentage reported as inhibition, in the whole organism at one dose (the size of the read-out at that dose, not a potency): 73.6%
Compound 3: middle estimate off by 28.6 percentage points, on the low side; measured number outside the range, above it.
By their numbers in this assay, from the lowest: compound 2; then compounds 1 and 3 (each within the scatter of the next).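

In this assay the aryl group on the carbon with a double bond to nitrogen clearly matters: 4-fluorophenyl in place of 3,4-dichlorophenyl gives a number 39.4 percentage points higher from compound 2 to compound 3 (beyond the scatter) and is a large step. Fluoro in place of phenoxy on the aromatic carbon gives a number 7.9 percentage points higher from compound 1 to compound 3 (within the scatter) and so does not separate these two groups at this dose. Nothing at hand explains either step. Open, from the compounds shown here alone, is whether 4-chlorophenyl would read like 3,4-dichlorophenyl or like 4-fluorophenyl, which would show how much of the large step follows the halogen and how much the substitution pattern. Also open, going by these compounds, is how a methoxy group or an amine on the same aromatic carbon would read.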